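The compounds below may be only part of what the source reports. "The series", "measured", "known", "first", "only" and "open" are said of these compounds alone.

In an assay on CHO cells for displacement of a labelled ligand from adenosine receptor A1 (Homo sapiens), read by scintillation counting, with a stated time of 120 min, tested at 10 uM (a lower number here means less inhibition, a higher number more inhibition at the concentration tested (going by the name of the read-out)), the three measured compounds gave the following:

Compound 1 `COc1ccc(N2CCN(Cc3csc(N)c3C(=O)c3ccc(Cl)cc3)CC2)cc1`: 0%
Compound 2 `Nc1scc(CN2CCN(c3ccc(OC(F)(F)F)cc3)CC2)c1C(=O)c1ccc(Cl)cc1`: 0%
Compound 3 `Nc1scc(CN2CCN(c3c(F)cccc3F)CC2)c1C(=O)c1ccc(Cl)cc1`: 1%

Compound 3 holds the largest of these three numbers, yet its gaps to compound 1 and to compound 2 both lie within the scatter, so all three show essentially no inhibition. Compound 4 `Nc1scc(CN2CCN(c3ccc(Cl)c(Cl)c3)CC2)c1C(=O)c1ccc(Cl)cc1` differs from compound 3 only in the aryl group on the ring amine nitrogen: 3,4-dichlorophenyl in place of 2,6-difluorophenyl on an amine nitrogen in a ring. Two measured steps change that same group: a number 1 percentage points higher from compound 1 to compound 3 (within the scatter) and a number 1 percentage points higher from compound 2 to compound 3 (within the scatter). Neither moved the read-out beyond the scatter. Because a number 1 percentage points higher from compound 1 to compound 3 (within the scatter) and a number 1 percentage points higher from compound 2 to compound 3 (within the scatter) were both flat, compound 4 is expected to stay flat as well, with an expected step of a number 1 percentage points higher from compound 3 to compound 4 (within the scatter). Compound 4 is therefore estimated at 2%, within a range from -8% to 12%.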

Compound 4, a percentage reported as inhibition, at one concentration (the size of the read-out at that concentration, not a potency): 1%
Compound 4: the middle estimate sits 1 percentage points above what was measured; the measured number falls inside the stated range.
By their numbers in this assay, from the lowest: compounds 1, 2, 3 and 4 (each within the scatter of the next).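

In this assay, placing 3,4-dichlorophenyl on the amine nitrogen in the ring gives no change at the digits printed from compound 3 to compound 4 (within the scatter), a number 1 percentage points higher from compound 2 to compound 4 (within the scatter) and a number 1 percentage points higher from compound 1 to compound 4 (within the scatter). Chlorine on the phenyl ring therefore joins methoxy, trifluoromethoxy and fluorine: across these four compounds, no step between aryl groups at this position exceeds the scatter. No measurement shown offers an explanation for this flat result.

The compounds leave open whether a non-aryl group at this position, such as a carboxylic acid or a longer chain ending in an amine, would give real inhibition. Changes elsewhere on the shared core also remain open.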